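Sulfamoyl for chloro on the N-aryl ring of the series

The source may hold more compounds than are shown below. What is called first, only, known or untested is meant among the compounds shown, and "the series" means these compounds.

Measured so far:
compound 1 `COc1ccc(-c2nn(-c3ccc(Cl)cc3)cc2C(CC(=O)c2ccc(Cl)cc2)C(=O)c2ccc(F)cc2)cc1` — 19.8%
compound 2 `COc1ccc(C(=O)C(CC(=O)c2ccc(Cl)cc2)c2cn(-c3ccc(Cl)cc3)nc2-c2ccc(OC)cc2)cc1` — 0%

Among the measured compounds shown here, in a functional assay on the whole organism (strain Wistar albino) for inhibition, with Rattus norvegicus as the target, read by paw edema, with stated times of 1 h and 2 h, at a dose of 0.32 mmol/kg by the intraperitoneal route (a higher number here means more inhibition at the dose given (going by the name of the read-out), a lower number less inhibition), compound 2 gives 0%, the lower of the two numbers; compound 1 gives 19.8%, and the one step available is a number 19.8 percentage points lower from compound 1 to compound 2 (beyond the scatter). Compound 3 `COc1ccc(C(=O)C(CC(=O)c2ccc(Cl)cc2)c2cn(-c3ccc(S(N)(=O)=O)cc3)nc2-c2ccc(OC)cc2)cc1` is yet to be measured. It differs from compound 2 by sulfamoyl in place of chloro on an aromatic carbon. For the measured compounds named here, no measured step bears on this change; the only step known concerns a different ring and a different pair of groups. Compound 2 sits at the floor of the read-out, so scatter can only show as a rise. For compound 3 an expected step of a number 10 percentage points higher from compound 2 to compound 3 (within the scatter), not beyond the scatter, is the working assumption. The estimate for compound 3 is 10%, within 0% to 30%.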

Compound 3, a percentage reported as inhibition, in the whole organism at one dose (the size of the read-out at that dose, not a potency): 30.8%
The estimate for compound 3 lay 20.8 percentage points below the measured number; the measured number lies above the stated range.
By their numbers in this assay, from the lowest: compound 2; then compound 1; then compound 3.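

In this assay, 4-sulfamoylphenyl in place of 4-chlorophenyl gives a number 30.8 percentage points higher from compound 2 to compound 3 (beyond the scatter) and shows that this place on the series can move the read-out, which the earlier step on a different ring could not show. The gain appears with the methoxy-bearing aryl ketone unchanged. Nothing available explains the rise.

Going by these compounds, whether sulfamoyl gives a similar step alongside the fluoro-bearing aryl ketone of compound 1 stays open. Also open, on these data alone, is whether the sulfamoyl group itself is needed, or whether a carboxylic acid or methylsulfonyl at this place would serve equally.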